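The source may hold more compounds than are shown below. What is called first, only, known or untested is meant among the compounds shown, and "the series" means these compounds.

In a functional assay on A549 cells (Homo sapiens) for inhibition, read by MTT assay, with a stated time of 48 h (a lower number here means a stronger inhibitor, a higher number a weaker inhibitor), three compounds built on a shared core have been measured: compound 1 `C(=C/c1nc2ccccn2c1Sc1ccccc1)\c1ccccc1` gives 16300 nM, compound 2 `CSc1ccc(-c2nc3ccccn3c2Sc2ccccc2)cc1` gives 13600 nM and compound 3 `Clc1ccc(-c2nc3ccccn3c2Sc2ccccc2)cc1` gives 22000 nM. Compound 3 therefore lies within the scatter of both other compounds. Compound 4 `c1ccc(Sc2c(-c3ccsc3)nc3ccccn23)cc1` has thiophen-3-yl in place of the 4-chlorophenyl of compound 3, on an aromatic carbon: thiophen-3-yl in place of 4-chlorophenyl on an aromatic carbon. Two measured steps exchange the whole group at this carbon, a 1.2-fold lower number from compound 1 to compound 2 (0.08 log units; within the scatter) and a 1.3-fold higher number from compound 1 to compound 3 (0.13 log units; within the scatter). A third, a 1.6-fold higher number from compound 2 to compound 3 (0.21 log units; within the scatter), has chloro in place of methylsulfanyl. All three stay within the scatter, so the group at this place has so far shown no measurable effect on the numbers in this assay. Within the data shown here, none of the measured compounds carries a thiophen-3-yl, so this reading is indirect. No change beyond the scatter is therefore expected, and the direction is left open. The estimated change is a 1.2-fold lower number from compound 3 to compound 4 (0.09 log units; within the scatter). Compound 4 is expected at about 18000 nM, with an estimated range from 9000 nM to 36000 nM.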

Compound 4, half-maximal inhibitory concentration: 72900 nM
The estimate for compound 4 lay 4.1-fold (0.61 log units) below the measured number; measured number outside the range, above it.
By their numbers in this assay, from the lowest: compounds 2, 1 and 3 (each within the scatter of the next); then compound 4.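

In this assay thiophen-3-yl in place of 4-chlorophenyl gives a 3.3-fold higher number from compound 3 to compound 4 (0.52 log units; beyond the scatter) and in place of 4-(methylsulfanyl)phenyl it gives a 5.4-fold higher number from compound 2 to compound 4 (0.73 log units; beyond the scatter) while in place of 2-phenylethenyl it gives a 4.5-fold higher number from compound 1 to compound 4 (0.65 log units; beyond the scatter) so the group at this carbon can move the number beyond the scatter after all. Compound 4 is thus the weakest inhibitor of the four, while the three larger groups compared earlier stay within the scatter of one another. No evidence is available on why this exchange raises the number.

Going by these compounds, whether the higher number belongs to thiophen-3-yl itself or to any five-membered aromatic ring at this place remains open. Also open, on these data alone, is how furan-3-yl, plain phenyl, or a phenyl carrying an amine or a carboxylic acid would read here.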